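The source may report more compounds than this note shows. Statements on the series, on what has been measured and on what is new or still open speak of the compounds shown alone.

Measured in a functional assay on HeLa cells (Homo sapiens) for antiproliferative activity, read by MTT assay, with a stated time of 48 h; on this read-out lower numbers stand for stronger inhibition of growth and higher numbers for weaker inhibition of growth:
Compound 1 `CCCOC(=O)N1N=C(c2cccc(OC)c2)CC1c1cc(OC)c(OC)c(OC)c1`: > 10000 nM, a limit of the assay.
Compound 2 `CCCOC(=O)N1N=C(c2ccc(OC)cc2)CC1c1cc(OC)c(OC)c(OC)c1`: > 10000 nM, a limit of the assay.
Compound 3 `CCOC(=O)N1N=C(c2cccc(O)c2)CC1c1cc(OC)c(OC)c(OC)c1`: 3280 nM.

For the measured compounds named here, compound 3, at 3280 nM, is the only compound with an actual number in this assay. The rest of the set sits at a ceiling: the limit of > 10000 nM in this assay, at which 2 of the 3 values shown sit.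

Compound 4 `CCCOC(=O)N1N=C(c2cccc(O)c2)CC1c1cc(OC)c(OC)c(OC)c1` departs from compound 3 by a single change, (methyl in place of hydrogen on a saturated chain carbon, two bonds along the chain from an oxygen next to a carbonyl group), which takes ethoxy to propoxy.

Going by the values given here, the one measured step, a step that the two limits leave unreadable from compound 1 to compound 2, lies at another place in the structure and has no readable size, so no measured step gives the size of this change directly. The only indirect hint is the propoxy group shared with compound 1 and compound 2, both of which differ from compound 4 elsewhere as well.

Compound 1 carries propoxy and reads > 10000 nM, a limit of the assay. Compound 2 also carries propoxy and reads > 10000 nM, likewise a limit.

On this thin basis, a modest move towards weaker inhibition of growth is expected in this assay. The expected step is a 1.7-fold higher number from compound 3 to compound 4 (0.22 log units; within the scatter). The estimate for compound 4 is 5500 nM, with an expected range of 2000 nM to 12000 nM.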

Compound 4, concentration for 50% growth inhibition: > 10000 nM
Compound 4 was reported as a limit (the forecaster's own chance of this, stated with the estimate: 35%); at least 1.8-fold (0.25 log units) between middle value and limit.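

In this assay, for the compounds shown here, the ethoxy to propoxy change gives an at least 3.0-fold higher number from compound 3 to compound 4 (0.48 log units; beyond the scatter) and is the first step with a readable size. The 3-hydroxyphenyl group does not keep a measurable value once propoxy is present, which compound 1 and compound 2 could not show, as both also differ from compound 3 on the aromatic ring. As far as these compounds go, compound 4 is reported only as a limit, so the full size of the step stays unknown, and the steps among compound 1, compound 2 and compound 4 cannot be read: the limit of > 10000 nM in this assay, at which 3 of the 4 values shown sit.

Open, from the compounds shown here alone, is how a shorter methoxy or a longer butoxy in place of ethoxy would read against compound 3 . Also open, going by these compounds, is how the 3-methoxyphenyl and 4-methoxyphenyl groups would read with ethoxy, where a number might separate the two.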